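The source may report more compounds than this note shows. Statements on the series, on what has been measured and on what is new or still open speak of the compounds shown alone.

The study concerns a small set of nucleoside analogues, each carrying a furan-type group on a bicyclic core, tested in a functional assay on CEM-DNR-bulk cells (Homo sapiens), read by MTT assay, with a stated time of 72 h; on this read-out higher numbers stand for weaker inhibition and lower numbers for stronger inhibition. Compound 1 has the structure `O=c1[nH]cnc2c1c(-c1ccoc1)cn2[C@@H]1O[C@H](CO)[C@@H](O)[C@H]1O`. In this assay compound 1 gives only a limit, > 20000 nM. Compound 3, `O=c1[nH]cnc2c1c(-c1cc3ccccc3o1)cn2[C@@H]1O[C@H](CO)[C@@H](O)[C@H]1O`, differs from compound 1 by one change: 1-benzofuran-2-yl in place of furan-3-yl on an aromatic carbon. In this assay compound 3 also reaches only a limit, > 20000 nM. The step between them, a step that the two limits leave unreadable from compound 1 to compound 3, cannot be sized because of the limit of > 20000 nM in this assay, at which 3 of the 3 values shown sit.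

Compound 2, `Cc1nc(N)c2c(-c3ccoc3)cn([C@@H]3O[C@H](CO)[C@@H](O)[C@H]3O)c2n1`, is built on a different core; how the two cores differ is not broken down here. In this assay compound 2 likewise stops at a limit, > 20000 nM. Compound 4, `Cc1nc(N)c2c(-c3cc4ccccc4o3)cn([C@@H]3O[C@H](CO)[C@@H](O)[C@H]3O)c2n1`, has not yet been measured in this assay. It relates to compound 2 through the same change that leads from compound 1 to compound 3: 1-benzofuran-2-yl in place of furan-3-yl on an aromatic carbon.

The step from compound 2 to compound 4 is expected to be a step that the limit leaves unreadable from compound 2 to compound 4, set beside the earlier one, an expectation resting on the fact that every measured compound sits at the limit of > 20000 nM in this assay, at which 3 of the 3 values shown sit, and that the earlier step from compound 1 to compound 3 remained unreadable. For compound 4 the estimate in this assay is therefore 30000 nM, expected to lie between 10000 nM and 100000 nM, and most likely to be reported as yet another limit rather than a number.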

Compound 4, half-maximal inhibitory concentration: 6310 nM
The estimate for compound 4 lay 4.8-fold (0.68 log units) above the measured number; the whole stated range lies above it.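

In this assay, putting 1-benzofuran-2-yl in place of furan-3-yl on an aromatic carbon of the second core gives an at least 3.1-fold lower number from compound 2 to compound 4 (0.50 log units; beyond the scatter), so on that core the change brings a measurable number out of a set of compounds otherwise held at a limit. This shows that the enlarged group, with its added six-membered aromatic ring of carbon only, is compatible with activity in these cells on one of the two cores, but it rests on a single pair, and the printed size is only a lower bound on the true step. It does not show whether the change carries from one core to the other with the same size or a different one, since the matching step on the core of compound 1 cannot be read, and that comparison stays closed because both of its ends sit at the ceiling of the assay: the limit of > 20000 nM in this assay, at which 3 of the 4 values shown sit.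

The compounds shown leave open whether a different group on the same aromatic carbon, such as phenyl, thiophen-2-yl or an amine, would give a readable number on either core. They also leave open which feature separating the two cores allows compound 4 to register while compound 3 stays at a limit.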